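Methyl for dimethoxy on the enone aryl of compound 3

The source may hold more compounds than are shown below. What is called first, only, known or untested is meant among the compounds shown, and "the series" means these compounds.

Compound 3 `COc1ccc(/C=C/C(=O)c2cc(-c3cc(OC)c(OC)c(OC)c3)n3nc(-c4ccccc4)cc3n2)cc1OC` gives 20500 nM in a functional assay on A549 cells (Homo sapiens) for antiproliferative activity, read by MTT assay, with a stated time of 24 h; a higher number here means a weaker inhibitor, a lower number a stronger inhibitor. Its number sits within the scatter of both other measured compounds: compound 1 `COc1ccc(C(=O)/C=C/c2cc(-c3cc(OC)c(OC)c(OC)c3)n3nc(-c4ccccc4)cc3n2)cc1` gives 14600 nM and compound 2 `COc1cc(-c2cc(/C=C/C(=O)c3ccc(C)cc3)nc3cc(-c4ccccc4)nn23)cc(OC)c1OC` gives 19400 nM in this assay, so no ordering among the three is supported. For the measured compounds named here, the one single-place step in the set, a 1.3-fold higher number from compound 1 to compound 2 (0.12 log units; within the scatter), exchanges a methoxy for a methyl on the aryl of the enone and stays within the scatter. Compound 4 `COc1cc(-c2cc(C(=O)/C=C/c3ccc(C)cc3)nc3cc(-c4ccccc4)nn23)cc(OC)c1OC` is reached from compound 3 by 4-methylphenyl in place of 3,4-dimethoxyphenyl on a double-bonded chain carbon bound to a double-bonded chain carbon. Going by the values given here, this removes two methoxy groups and puts in a methyl, a larger change than the step between compound 1 and compound 2, but the only comparable evidence in this assay is that step, and it showed nothing beyond the scatter. A step of no size beyond the scatter is therefore expected from compound 3 to compound 4, a 1.0-fold lower number from compound 3 to compound 4 (0.01 log units; within the scatter). Compound 4 is expected to give 20000 nM in this assay, within a range from 9000 nM to 45000 nM.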

Compound 4, half-maximal inhibitory concentration: 20000 nM
The estimate for compound 4 equals the measured number at the digits printed; measured number inside the range.
By their numbers in this assay, from the lowest: compounds 1, 2, 4 and 3 (each within the scatter of the next).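

In this assay, 4-methylphenyl in place of 3,4-dimethoxyphenyl on a double-bonded chain carbon bound to a double-bonded chain carbon gives a step within the scatter (a 1.0-fold lower number from compound 3 to compound 4 (0.01 log units; within the scatter)), so this larger aryl change, with the carbonyl bound to the core, separates nothing. For the compounds shown here, with the 4-methylphenyl held constant, turning the enone round gives the first reading of orientation alone (a 1.0-fold higher number from compound 2 to compound 4 (0.01 log units; within the scatter)), and the same turn combined with methyl for methoxy also stays within the scatter (a 1.4-fold higher number from compound 1 to compound 4 (0.14 log units; within the scatter)). No measurement in hand gives a cause for these readings.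

Open, going by these compounds, is whether an amine or a carboxylic acid on this aryl would give a step beyond the scatter. Equally open, on these data alone, is whether a longer chain in place of the enone would do so.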